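A Bromophenyl Group Returns to the Inactive Compound

The compounds below may be only part of what the source reports. "The series", "measured", "known", "first", "only" and "open" are said of these compounds alone.

Values in a functional assay on PC-3 cells (Homo sapiens) for inhibition, read by MTT assay, with a stated time of 48 h, tested at 10 uM; a lower number here means less inhibition of growth, a higher number more inhibition of growth at the concentration tested:
Compound 1 `Cc1oc2c([C@H]3CCN(C)C[C@H]3O)c(O)cc(O)c2c(=O)c1C(O)c1ccc(F)c(Br)c1`: 72%
Compound 2 `Cc1oc2c([C@H]3CCN(C)C[C@H]3O)c(O)cc(O)c2c(=O)c1C(O)c1c(F)cccc1Cl`: 0%

Compound 2 stands lowest of the two, at 0%. Compound 3 `COc1ccc(C(O)c2c(C)oc3c([C@H]4CCN(C)C[C@H]4O)c(O)cc(O)c3c2=O)cc1Br` replaces its 2-chloro-6-fluorophenyl with 3-bromo-4-methoxyphenyl, on a saturated chain carbon bound to an aromatic carbon and an oxygen on a saturated carbon: 3-bromo-4-methoxyphenyl in place of 2-chloro-6-fluorophenyl on a saturated chain carbon bound to an aromatic carbon and an oxygen on a saturated carbon. Going by the values given here, one measured step bears on this, the large drop a number 72 percentage points lower from compound 1 to compound 2 (beyond the scatter), which brought in 2-chloro-6-fluorophenyl at that same place in exchange for 3-bromo-4-fluorophenyl. Compound 3 largely reverses that exchange, yet with methoxy where compound 1 has fluoro, and no measurement covers that difference. A large rise in this assay is therefore expected, somewhat short of the full size of that drop: a number 55 percentage points higher from compound 2 to compound 3 (beyond the scatter). The estimate for compound 3 is 55%, with an expected range of 20% to 85%.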

Compound 3, percent growth inhibition at one concentration: 0%
Compound 3: the middle estimate sits 55 percentage points above what was measured; the measured number lies below the stated range.
By their numbers in this assay, from the lowest: compounds 2 and 3 (each within the scatter of the next); then compound 1.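

Putting 3-bromo-4-methoxyphenyl in place of 2-chloro-6-fluorophenyl on that saturated chain carbon did not bring growth inhibition back in this assay: the step reads no change at the digits printed from compound 2 to compound 3 (within the scatter). The bromo group therefore does not suffice on its own here, since methoxy in place of fluoro on an aromatic carbon, the only difference between these two compounds, comes with a number 72 percentage points lower from compound 1 to compound 3 (beyond the scatter). No measurement of any kind is available to explain why this single exchange matters so much.

The compounds shown leave open whether inhibition depends on fluoro specifically or would also survive with a chloro, a hydroxyl or an amine in its place. They also leave open whether the bromo group contributes at all, a question that 4-fluorophenyl without bromo would address.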